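Swapping chloro for tert-butyl on a weak inhibitor

The source may hold more compounds than are shown below. What is called first, only, known or untested is meant among the compounds shown, and "the series" means these compounds.

Of the compounds shown here, three have been measured in an assay on isolated protein for inhibition of alpha-ketoglutarate-dependent dioxygenase alkB homolog 3 (Homo sapiens), read by polymerase chain reaction, with a stated time of 1 h; a lower number here means a stronger inhibitor, a higher number a weaker inhibitor. Compound 1 `COc1ccc(Cc2c(C)[nH]n(-c3nc4ccccc4[nH]3)c2=O)cc1` gives 630 nM, compound 2 `Cc1[nH]n(-c2nc3cc(Cl)ccc3[nH]2)c(=O)c1Cc1ccccc1` gives 4500 nM, and compound 3 `Cc1ccc2[nH]c(-n3[nH]c(C)c(Cc4ccc(C(F)(F)F)cc4)c3=O)nc2c1` gives 570 nM. Compound 2 stands at the highest number of the three, so it is the weakest inhibitor of the set; both compound 1 and compound 3 lie beyond the scatter from it.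

Compound 4 `Cc1[nH]n(-c2nc3cc(C(C)(C)C)ccc3[nH]2)c(=O)c1Cc1ccccc1` differs from compound 2 in one place: tert-butyl in place of chloro on an aromatic carbon. Going by the values given here, no measured pair shows the effect of this exact change, so the direction is uncertain. The closest hint is compound 3, which carries a methyl on the same fused ring system and reaches a lower number than compound 2, but it also differs elsewhere, so that comparison cannot be read as a clean step. The expected step in this assay from compound 2 to compound 4 is therefore small, a 1.5-fold lower number from compound 2 to compound 4 (0.18 log units; within the scatter), and may not exceed the scatter. Compound 4 is estimated at 3000 nM, within a range from 800 nM to 12000 nM.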

Compound 4, half-maximal inhibitory concentration: 640 nM
Compound 4: the middle estimate sits 4.7-fold (0.67 log units) above what was measured; measured number below the stated range.
By their numbers in this assay, from the lowest: compounds 3, 1 and 4 (each within the scatter of the next); then compound 2.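

Going by these compounds alone, this is the first clean reading of this position, the aromatic carbon of the fused ring system. In this assay, tert-butyl in place of chloro gives a 7.0-fold lower number from compound 2 to compound 4 (0.85 log units; beyond the scatter), a step beyond the scatter. For this one pair, a group of four heavy atoms is therefore accepted here in place of a single chlorine, and the larger group comes with the stronger inhibition. No measurement shown here accounts for this change.

One pair cannot tell whether this result is particular to tert-butyl or would also appear with other groups on this carbon, such as an ethyl, an isopropyl or an amine. It also leaves open whether the same swap would give a similar step if the rest of the molecule were different.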